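The source may hold more compounds than are shown below. What is called first, only, known or untested is meant among the compounds shown, and "the series" means these compounds.

Measured so far in a functional assay on the whole organism (stomach) with Rattus norvegicus as the target; on this read-out higher numbers stand for an effect only at larger amounts of compound and lower numbers for an effect already at smaller amounts:
- compound 1 `C/N=C(\NC#N)NCCCCn1nc(-c2ccccc2)ccc1=O` gives 32.4 mg/kg
- compound 2 `C/N=C(/NC#N)N(C)CCCCn1nc(-c2ccccc2)ccc1=O` gives only a limit of the assay, > 100 mg/kg
- compound 3 `CN(C)/C(=N/CCCCCn1nc(-c2ccccc2)ccc1=O)NC#N` gives 81.5 mg/kg

Compound 3 stands highest of the two numbers in this assay; compound 1 gives a lower number, and the gap is beyond the scatter. Compound 2 contributes a limit only (the limit of > 100 mg/kg in this assay, at which 1 of the 3 values shown sits).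

Compound 4 `C/N=C(/NC#N)NCCCCCn1nc(-c2ccccc2)ccc1=O` is the next member. It differs from compound 3 as follows (a group of 7 heavy atoms (3 carbon, 4 nitrogen; no ring) in place of a group of 8 heavy atoms (4 carbon, 4 nitrogen; no ring), on a saturated chain carbon, five bonds along the chain from an aromatic nitrogen).

Among the measured compounds shown here, one measured step bears on this change: an at least 3.0-fold higher number from compound 1 to compound 2 (0.48 log units; beyond the scatter). There a methyl was added on the guanidine nitrogen and the number moved upward beyond the scatter, to a limit. The change from compound 3 to compound 4 takes a methyl away from the same kind of position, so a step in the opposite direction, downward, of modest size is expected, and compound 4 is expected to give a lower number than compound 3 by about a 2.3-fold lower number from compound 3 to compound 4 (0.37 log units; beyond the scatter).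

For compound 4 in this assay the estimate is 35 mg/kg, with a likely range from 15 mg/kg to 80 mg/kg.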

Compound 4, dose for half-maximal effect: 100 mg/kg
Beside the measured number, compound 4's estimate is 2.9-fold (0.46 log units) below it; the whole stated range lies below it.
By their numbers in this assay, from the lowest: compound 1; then compounds 3 and 4 (each within the scatter of the next).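

In this assay, the group of 7 heavy atoms in place of the group of 8 heavy atoms, five bonds along the chain from an aromatic nitrogen, gives a 1.2-fold higher number from compound 3 to compound 4 (0.09 log units; within the scatter), a step within the scatter, whereas an at least 3.0-fold higher number from compound 1 to compound 2 (0.48 log units; beyond the scatter) at the four-bond place lies beyond the scatter. The group at the four-bond place in compound 1, set against compound 4, gives a 3.1-fold higher number from compound 1 to compound 4 (0.49 log units; beyond the scatter), which places the readable difference in this small set at the position of the group on the chain rather than at the methyl. Compound 2 gives a limit: the limit of > 100 mg/kg in this assay, at which 1 of the 4 values shown sits. The remaining step, a number no higher from compound 2 to compound 4 (the limit leaves the size open), cannot be read.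

A shorter chain would test whether the methyl matters only at the four-bond place. As far as these compounds go, an ethyl on the same nitrogen, or an amine in place of the whole group, remains open.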